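This account rests on a few compounds, and the source may have more. Where it says the series, first, only, none or still open, it means among the compounds named here.

Compound 1 `CNc1nc(=O)ccn1[C@@H]1O[C@H](COP(=O)(O)O)[C@@H](O)[C@H]1O`, compound 2 `O=c1ccn([C@@H]2O[C@H](COP(=O)(O)O)[C@@H](O)[C@H]2O)c(SCCc2ccccc2)n1` and compound 3 `O=c1ccn([C@@H]2O[C@H](COP(=O)(O)O)[C@@H](O)[C@H]2O)c(SCc2ccccc2)n1` share one core and differ only in the group on its aromatic carbon. In an in vitro functional assay on 1321-N1 cells for agonist activity at P2Y purinoceptor 6 (Homo sapiens), read by scintillation proximity assay and inositol phosphate accumulation (a higher number here means that more compound is needed for the effect, a lower number that less compound is needed), compound 1 reaches only the limit of the assay, > 100000 nM. In this assay compound 2 likewise gives only the limit, > 100000 nM. Compound 3 too stands at the limit in this assay, > 100000 nM. Compound 4 `CCCSc1nc(=O)ccn1[C@@H]1O[C@H](COP(=O)(O)O)[C@@H](O)[C@H]1O` differs from compound 3 by ethyl in place of phenyl on a saturated chain carbon bound to a sulfur. Among the measured compounds shown here, the one measured step at that place, a step that the two limits leave unreadable from compound 2 to compound 3, is unreadable because of the limit of > 100000 nM in this assay, at which 3 of the 3 values shown sit. For the measured compounds named here, no sized step therefore guides the expectation. Compound 4 is expected to stay near the same limit, at an estimated 150000 nM in this assay, between 30000 nM and 1000000 nM. The expected step that the limit leaves unreadable from compound 3 to compound 4 is thus estimated as none beyond the scatter.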

Compound 4, half-maximal effective concentration: 6200 nM
Estimate against measurement, compound 4: 24-fold (1.38 log units) above, outside the stated range (below it).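

Propylsulfanyl in place of methylamino on the aromatic carbon gives an at least 16-fold lower number from compound 1 to compound 4 (1.20 log units; beyond the scatter) in this assay, which shows that this place can carry a group giving a readable value. Among the sulfur-linked chains, ethyl in place of phenyl gives an at least 16-fold lower number from compound 3 to compound 4 (1.20 log units; beyond the scatter) and methyl in place of phenyl gives an at least 16-fold lower number from compound 2 to compound 4 (1.20 log units; beyond the scatter), so only the chain without phenyl leaves the limit, though compound 1 also lacks phenyl and stays there. The steps among compound 1, compound 2 and compound 3 cannot be read: the limit of > 100000 nM in this assay, at which 3 of the 4 values shown sit.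

On these data alone, it remains open whether a butylsulfanyl or longer chain would lower the number further. As far as these compounds go, whether propylamino could replace propylsulfanyl also remains open.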